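A few compounds are considered here, and "the series" means these few. Any claim that something is new, unique, unknown or untested is made for them only; others in the source may bear on it.

Of the compounds shown here, three built on one shared core have been tested in a functional assay on M21 cells (Homo sapiens) for antiproliferative activity, read by sulforhodamine B assay, with a stated time of 48 h; on this read-out higher numbers stand for weaker inhibition and lower numbers for stronger inhibition. Compound 1 `CCc1ccccc1OS(=O)(=O)c1ccc(N2CCN(C)C2=O)cc1` gives 2300 nM in this assay. Compound 2 `CN1CCN(c2ccc(S(=O)(=O)Oc3c(Cl)cc(Cl)cc3Cl)cc2)C1=O` gives 1700 nM, a number that lies within the usual scatter of compound 1, so the two cannot be told apart. Compound 3 `COc1ccc(OS(=O)(=O)c2ccc(N3CCN(C)C3=O)cc2)cc1OC` gives 8500 nM, a number clearly higher than that of compound 1, meaning weaker inhibition. Among the three numbers, compound 1 therefore stands second highest, close to compound 2 and well apart from compound 3.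

Compound 4 `Cc1ccc(OS(=O)(=O)c2ccc(N3CCN(C)C3=O)cc2)cc1` has not yet been measured. It differs from compound 1 in one place, on an oxygen whose other neighbour is the sulfonyl sulfur: 4-methylphenyl in place of 2-ethylphenyl on an oxygen. Within the data shown here, no measured pair shows this kind of change, so there is no direct guide to its size. Given that the three known numbers spread only modestly, compound 4 is expected to stay near compound 1, with a step from compound 1 to compound 4 of a 1.1-fold higher number from compound 1 to compound 4 (0.04 log units; within the scatter), not beyond the scatter in either direction. Compound 4 is estimated at 2500 nM, within a range of 1000 nM to 6500 nM.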

Compound 4, half-maximal inhibitory concentration: > 100000 nM
Compound 4: only a limit was reported (the forecaster's own chance of this, stated with the estimate: 5%); middle value at least 40-fold (1.60 log units) from the limit.
By their numbers in this assay, from the lowest: compounds 2 and 1 (each within the scatter of the next); then compound 3. At a limit, above all of these: compound 4.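

Compound 4 is reported in this assay only as a limit, > 100000 nM. The change of 2-ethylphenyl to 4-methylphenyl on the oxygen whose other neighbour is the sulfonyl sulfur gives an at least 43-fold higher number from compound 1 to compound 4 (1.63 log units; beyond the scatter), so a single swap at this position can have a large effect even though both groups carry one six-membered aromatic ring of carbon only and neither has hydrogen-bond donors or acceptors. The earlier compounds offered no step at this position, and this one is a minimum rather than a true size: the limit of > 100000 nM in this assay, at which 1 of the 4 values shown sits.

The change alters both the chain, ethyl to methyl, and its place on the ring, and this single step cannot separate the two. As far as these compounds go, a 2-methylphenyl or 4-ethylphenyl group on the same oxygen would address that question, and how a ring bearing an amine would behave also remains open.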